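Cyclopentyl for Phenyl at the Saturated Ring Carbon

The compounds below may be only part of what the source reports. "The series", "measured", "known", "first", "only" and "open" are said of these compounds alone.

Values so far in an assay on HEK293 cells for displacement of a labelled ligand from adenosine receptor A2b (Homo sapiens), with a stated time of 30 min, tested at 1 uM; on this read-out lower numbers stand for less inhibition and higher numbers for more inhibition at the one concentration tested (going by the name of the read-out):

compound 1 `CC1=C(C(=O)OC(C)C)C(C2CCCC2)N/C(=N/C#N)N1` gives 11%
compound 2 `CCOC(=O)C1=C(C)N/C(=N\C#N)NC1c1ccccc1` gives 25%
compound 3 `CC1=C(C(=O)OC(C)C)C(c2ccccc2)N/C(=N/C#N)N1` gives 32%

Compound 2 sits close to compound 3, since the step of a number 7 percentage points higher from compound 2 to compound 3 (within the scatter) lies within the scatter, while its gap to compound 1 is beyond the scatter, compound 1 lying lower.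

Compound 4 `CCOC(=O)C1=C(C)N/C(=N\C#N)NC1C1CCCC1` is not yet measured in this assay. Relative to compound 2 the change is cyclopentyl in place of phenyl on a saturated ring carbon.

Going by the values given here, one measured step bears on this swap and runs the other way: a number 21 percentage points higher from compound 1 to compound 3 (beyond the scatter), a modest change beyond the scatter. A drop of similar size is therefore expected for compound 4, a number 21 percentage points lower from compound 2 to compound 4 (beyond the scatter).

Compound 4 is estimated at 4%, with a range from -8% to 16%.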

Compound 4, a percentage reported as inhibition, at one concentration (the size of the read-out at that concentration, not a potency): 19%
Beside the measured number, compound 4's estimate is 15 percentage points below it; measured number above the stated range.
By their numbers in this assay, from the lowest: compounds 1, 4, 2 and 3 (each within the scatter of the next, the first and the last beyond it).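

With the ethoxycarbonyl group in the core, cyclopentyl in place of phenyl on the saturated ring carbon gives only a number 6 percentage points lower from compound 2 to compound 4 (within the scatter), so in this assay this change does not carry over at one size between the cores: the same change on two cores in this assay, a number 21 percentage points higher (beyond the scatter) from compound 1 to compound 3 and a number 6 percentage points higher (within the scatter) from compound 4 to compound 2, 15 percentage points apart, beyond the scatter of two such steps

Hydrogen in place of methyl on the saturated chain carbon bound to the oxygen, read with cyclopentyl, gives a number 8 percentage points higher from compound 1 to compound 4 (within the scatter), and this step likewise depends on its partner group: the same change on two cores in this assay, a number 7 percentage points higher (within the scatter) from compound 2 to compound 3 and a number 8 percentage points lower (within the scatter) from compound 4 to compound 1, 15 percentage points apart, beyond the scatter of two such steps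

This dependence rests on one pair of cores only. On these data alone, how an amine, a carboxylic acid or a longer chain would behave on this saturated ring carbon remains open.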